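Methoxy for hydrogen on the aryl ring: two cores compared

This account rests on a few compounds, and the source may have more. Where it says the series, first, only, none or still open, it means among the compounds named here.

Compound 1 `CCOC(=O)N1N=C(c2ccccc2)CC1c1cc(OC)c(OC)c(OC)c1` and compound 2 `CCOC(=O)N1N=C(c2ccc(OC)cc2)CC1c1cc(OC)c(OC)c(OC)c1` share one core. In a functional assay on HT-29 cells (Homo sapiens) for antiproliferative activity, read by MTT assay, with a stated time of 48 h (on this read-out higher numbers stand for weaker inhibition of growth and lower numbers for stronger inhibition of growth), compound 1 gives 8920 nM and compound 2 gives 6730 nM. The change between them is methoxy in place of hydrogen on an aromatic carbon, and it made a 1.3-fold lower number from compound 1 to compound 2 (0.12 log units; within the scatter). Compound 3 `COC(=O)N1N=C(c2ccccc2)CC1c1ccc(OC)c(OC)c1` stands on a second core; the difference between the two cores is not broken down here. In this assay compound 3 gives 10700 nM, within the scatter of both compound 1 and compound 2. Compound 4 `COC(=O)N1N=C(c2ccccc2)CC1c1cc(OC)c(OC)cc1OC` has not yet been measured; it differs from compound 3 by methoxy in place of hydrogen on an aromatic carbon. This is the same kind of change as from compound 1 to compound 2, not the same one: in compound 2 the entering methoxy sits para to a large group, whereas in compound 4 it sits ortho to a large group, meta to a methoxy group and para to a methoxy group. Among the measured compounds shown here, only one measured instance of this kind of change exists, and because a 1.3-fold lower number from compound 1 to compound 2 (0.12 log units; within the scatter) lies within the scatter, the expected step is a 1.2-fold lower number from compound 3 to compound 4 (0.08 log units; within the scatter). Compound 4 is therefore estimated at 9000 nM in this assay, with a likely range of 4000 nM to 20000 nM.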

Compound 4, concentration for 50% growth inhibition: 14900 nM
Compound 4: the middle estimate sits 1.7-fold (0.22 log units) below what was measured; measured number inside the range.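

In this assay methoxy in place of hydrogen gives a 1.4-fold higher number from compound 3 to compound 4 (0.14 log units; within the scatter), so neither instance of this change moves the number beyond the scatter. Set side by side, the two steps cannot be told apart: the same change on two cores in this assay, a 1.3-fold lower number (0.12 log units; within the scatter) from compound 1 to compound 2 and a 1.4-fold higher number (0.14 log units; within the scatter) from compound 3 to compound 4, 1.8-fold (0.27 log units) apart, within the scatter of two such steps. Among the compounds shown here, this shows that on these two cores the change produced no step that can be read, but it does not show that the change acts alike on both: the entering methoxy stands at a different place in each instance, and two steps within the scatter supply neither a direction nor a size to carry to a further core.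

The compounds shown leave open whether a different group on either aryl ring, such as an amine, a hydroxyl or a fluorine, would move the number beyond the scatter. They also leave open what a longer chain on the ester, or a carboxylic acid in its place, would do on these cores.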